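A Chloro Added to the Benzyl Group

The source may hold more compounds than are shown below. What is called first, only, known or untested is meant among the compounds shown, and "the series" means these compounds.

In a functional assay on RS4-11 cells (Homo sapiens) for inhibition, read by CCK-8 assay, with a stated time of 48 h, tested at 20 uM (on this read-out lower numbers stand for less inhibition of growth and higher numbers for more inhibition of growth at the one concentration tested), compound 3 (`N#C/C(=C\c1ccccc1OS(=O)(=O)c1ccc(F)cc1)C(=O)Nc1nnc(Cc2ccccc2)s1`) gives 69%, within the scatter of compound 1 (`N#C/C(=C\c1ccccc1OS(=O)(=O)c1ccccc1[N+](=O)[O-])C(=O)Nc1nnc(Cc2ccccc2)s1`) at 71% and compound 2 (`N#C/C(=C\c1ccccc1OS(=O)(=O)c1ccc(Cl)cc1)C(=O)Nc1nnc(Cc2ccccc2)s1`) at 73%. Compound 4 (`N#C/C(=C\c1ccccc1OS(=O)(=O)c1ccc(F)cc1)C(=O)Nc1nnc(Cc2ccc(Cl)cc2)s1`) differs from compound 3 in one place, chloro in place of hydrogen on an aromatic carbon, which turns benzyl to 4-chlorobenzyl. Within the data shown here, no measured step touches this group. The closest evidence comes from changes on the aryl group at the sulfonyl sulfur: a number 4 percentage points lower from compound 2 to compound 3 (within the scatter), a number 2 percentage points higher from compound 1 to compound 2 (within the scatter) and a number 2 percentage points lower from compound 1 to compound 3 (within the scatter). On these data alone, none of them leaves the scatter, so no step beyond the scatter is expected in this assay, although this site remains untested. For compound 4 the expected value is 72%, with an estimated range of 60% to 84%.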

Compound 4, percent growth inhibition at one concentration: 64%
Estimate against measurement, compound 4: 8 percentage points above, within the range that was stated.
By their numbers in this assay, from the lowest: compounds 4, 3, 1 and 2 (each within the scatter of the next).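

In this assay, among these compounds, the benzyl group, which no earlier step touched, now has a measured step of its own: 4-chlorobenzyl in place of benzyl gives a number 5 percentage points lower from compound 3 to compound 4 (within the scatter) at the one concentration tested. Chloro in place of hydrogen at this place therefore stays within the scatter, as the changes on the aryl group at the sulfonyl sulfur did. Nothing shown bears on why this result came out as it did. The compounds shown leave open how an amine or a carboxylic acid would read in place of chloro on this ring. They also leave open whether the chloro step would hold with 4-chlorophenyl or 2-nitrophenyl on the sulfonyl sulfur.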